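This account rests on a few compounds, and the source may have more. Where it says the series, first, only, none or still open, it means among the compounds named here.

In a functional assay on K562 cells (Homo sapiens), read by MTT assay, with a stated time of 72 h (on this read-out lower numbers stand for stronger inhibition and higher numbers for weaker inhibition), compound 3 `CN(C)c1ncnc2c1c(-c1cc3ccccc3o1)cn2[C@@H]1O[C@H](CO)[C@@H](O)[C@H]1O` reads > 20000 nM, which is a limit of the assay and not a number. Two relatives with the ethynyl group give measured values: compound 1 `C#Cc1cn([C@@H]2O[C@H](CO)[C@@H](O)[C@H]2O)c2ncnc(OC)c12` reaches 380 nM, and compound 2 `C#Cc1cn([C@@H]2O[C@H](CO)[C@@H](O)[C@H]2O)c2ncnc(NC)c12` reaches 1380 nM. The change now in question leads to compound 4 `C#Cc1cn([C@@H]2O[C@H](CO)[C@@H](O)[C@H]2O)c2ncnc(N(C)C)c12`: ethynyl in place of 1-benzofuran-2-yl on an aromatic carbon. In words, this is ethynyl in place of 1-benzofuran-2-yl on an aromatic carbon, and the rest of compound 3 stays as it is. For the measured compounds named here, no measured step holds this exchange itself. Going by the values given here, the only measured step is a 3.6-fold higher number from compound 1 to compound 2 (0.56 log units; beyond the scatter), a modest change made with the ethynyl group in place, and it points to values in the low micromolar region for this family rather than to the limit seen for compound 3. A large move toward stronger inhibition is therefore expected, landing somewhat on the weaker side of compound 2 at 1380 nM. The expected step is an at least 8.0-fold lower number from compound 3 to compound 4 (0.90 log units; beyond the scatter). Compound 4 is estimated at 2500 nM, within an expected range of 500 nM to 12000 nM.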

Compound 4, half-maximal inhibitory concentration: 260 nM
The estimate for compound 4 lay 9.6-fold (0.98 log units) above the measured number; the whole stated range lies above it.
By their numbers in this assay, from the lowest: compounds 4 and 1 (each within the scatter of the next); then compound 2. At a limit, above all of these: compound 3.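

In this assay, ethynyl in place of 1-benzofuran-2-yl on this aromatic carbon gives an at least 76-fold lower number from compound 3 to compound 4 (1.88 log units; beyond the scatter), the first direct measure of this exchange, and it shows that the choice of group at this carbon can carry the result from a limit to a measured value. With ethynyl held in place, the methyl added on the nitrogen gives a 5.3-fold lower number from compound 2 to compound 4 (0.72 log units; beyond the scatter), so the dimethylamino group does not extend the loss seen in the earlier step from methoxy to methylamino, and dimethylamino in place of methoxy gives a 1.5-fold lower number from compound 1 to compound 4 (0.16 log units; within the scatter), within the scatter. The reading for compound 3 is a limit and not a number, so the full size of its step stays unknown: the limit of > 20000 nM in this assay, at which 1 of the 4 values shown sits.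

The compounds shown leave open how a phenyl ring, a single furan ring or a longer alkyne chain would read at this carbon. They also leave open whether 1-benzofuran-2-yl would reach the same limit with methoxy or methylamino on the core.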